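This account rests on a few compounds, and the source may have more. Where it says the series, first, only, none or still open, it means among the compounds named here.

The series shares one core, and the three measured compounds differ only in the group on the carbonyl carbon attached to the ring nitrogen. Compound 1 `COc1ccc(-c2cn3cc(C4=CCN(C(=O)C5CCCCC5)CC4)ccc3n2)cc1OC` carries cyclohexyl there; in a functional assay on B16-F10 cells (Mus musculus) for antiproliferative activity, read by MTT assay, with a stated time of 48 h (on this read-out lower numbers stand for stronger inhibition and higher numbers for weaker inhibition), compound 1 gives 10900 nM. Compound 2 `COc1ccc(-c2cn3cc(C4=CCN(C(=O)C(C)(C)C)CC4)ccc3n2)cc1OC` carries tert-butyl, and compound 2 gives 7100 nM. Compound 3 `COc1ccc(-c2cn3cc(C4=CCN(C(=O)c5ccccc5)CC4)ccc3n2)cc1OC` carries phenyl, and compound 3 gives 8370 nM. The steps among them are small: a 1.5-fold lower number from compound 1 to compound 2 (0.19 log units; within the scatter), a 1.3-fold lower number from compound 1 to compound 3 (0.11 log units; within the scatter), and a 1.2-fold higher number from compound 2 to compound 3 (0.07 log units; within the scatter). Compound 3 thus sits among numbers that cannot be told apart, its value close to that of compound 2 and to that of compound 1, both gaps within the scatter.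

Compound 4 `COc1ccc(-c2cn3cc(C4=CCN(S(=O)(=O)c5ccccc5)CC4)ccc3n2)cc1OC` differs from compound 3 in one place: phenylsulfonyl in place of benzoyl on an amine nitrogen in a ring. Among the measured compounds shown here, none of the measured steps alters the linking group itself; each of them only swaps what sits on the carbonyl carbon, and each stayed within the scatter. For the measured compounds named here, there is therefore no measured step that speaks directly to putting phenylsulfonyl in place of benzoyl, and the nearest evidence is that every variation at this position has left the number essentially unmoved. The expected step from compound 3 to compound 4 is accordingly a 1.0-fold higher number from compound 3 to compound 4 (0.01 log units; within the scatter), with no direction favoured. Compound 4 is estimated at 8500 nM, in a range from 3000 nM to 25000 nM.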

Compound 4, half-maximal inhibitory concentration: 13200 nM
Compound 4: middle estimate off by 1.6-fold (0.19 log units), on the low side; low and high end bracket the measured number.
By their numbers in this assay, from the lowest: compounds 2, 3, 1 and 4 (each within the scatter of the next).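

Compound 4 is the only one shown in which the linking group itself changes, with a sulfonyl taking the place of the carbonyl. In this assay, phenylsulfonyl in place of benzoyl on an amine nitrogen in a ring gives a 1.6-fold higher number from compound 3 to compound 4 (0.20 log units; within the scatter), and the comparisons with the other two carbonyl compounds give a 1.9-fold higher number from compound 2 to compound 4 (0.27 log units; within the scatter) and a 1.2-fold higher number from compound 1 to compound 4 (0.08 log units; within the scatter). All three steps lie within the scatter, so across these four compounds neither the group on the link nor the link itself separates the numbers, and no measurement shown accounts for the small differences among them.

Still open, on these data alone, is whether a methylsulfonyl group, a phenylsulfonyl carrying chlorine or methoxy on its ring, or a urea on the same nitrogen would move the number beyond the scatter. Also open, as far as these compounds go, is whether the free ring amine would behave like these four compounds, since each of them keeps the shared core and carries a large group on that nitrogen.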